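Swapping a Cyclopentyl Ring for a Short Hydroxy Chain

The source may hold more compounds than are shown below. What is called first, only, known or untested is meant among the compounds shown, and "the series" means these compounds.

Of the compounds shown here, three sharing one core have been tested in an assay on isolated protein (Oryctolagus cuniculus) with Thromboxane-A synthase (Homo sapiens) as the target, tested at 1 uM; on this read-out higher numbers stand for more inhibition at the one concentration tested (going by the name of the read-out) and lower numbers for less inhibition. Compound 1 `Oc1nnc(-c2cccnc2)c2ccccc12` gives 26%. Compound 2 `O=c1c2ccccc2c(-c2cccnc2)nn1C1CCCC1` gives 97%, the top number of the three, though compound 3 `COC(=O)c1ccc(Cn2nc(-c3cccnc3)c3ccccc3c2=O)cc1` gives 95%, within the scatter of compound 2, while the gap down to compound 1 lies beyond it. Compound 4 `O=c1c2ccccc2c(-c2cccnc2)nn1CCO` is not yet measured; it differs from compound 2 by 2-hydroxyethyl in place of cyclopentyl on an aromatic nitrogen. Among the measured compounds shown here, no measured pair shows this exact change. Compound 2 gives 97% and compound 3 gives 95%, both carrying a group on that nitrogen, whereas compound 1 without one gives far less. A modest fall is therefore expected, the expected step being a number 22 percentage points lower from compound 2 to compound 4 (beyond the scatter). Compound 4 is expected to give about 75%, between 45% and 95%.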

Compound 4, a percentage reported as inhibition, at one concentration (the size of the read-out at that concentration, not a potency): 69%
Estimate against measurement, compound 4: 6 percentage points above; low and high end bracket the measured number.
By their numbers in this assay, from the lowest: compound 1; then compound 4; then compounds 3 and 2 (each within the scatter of the next).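

In this assay it matters which group sits on this aromatic nitrogen, not only whether one is there: 2-hydroxyethyl in place of cyclopentyl gives a number 28 percentage points lower from compound 2 to compound 4 (beyond the scatter) on that read-out. Even so, compound 4 at 69% stays well above compound 1 at 26% on the printed values, so this nitrogen needs no ring to keep much of the inhibition.

Still open, going by these compounds, is whether the fall follows the lost ring, the smaller group or the added hydroxyl, which a plain ethyl or a longer 3-hydroxypropyl chain could help separate. Nothing measured here explains the fall.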